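Benzoyl in place of phenoxyacetyl on the cyclohexyl ester

The source may report more compounds than this note shows. Statements on the series, on what has been measured and on what is new or still open speak of the compounds shown alone.

Measured compounds:
Compound 1 `CN(Cc1cn(C2CCCCC2OC(=O)c2ccccc2)nn1)CC1CCCCC1` gives 32% in an assay on nucleic acid for inhibition of Nucleic Acid, read by fluorescence, tested at 100 uM; on this read-out lower numbers stand for less inhibition and higher numbers for more inhibition at the one concentration tested (going by the name of the read-out).
Compound 2 `CC(C)CCN(C)Cc1cn(C2CCCCC2O)nn1` gives 42% in this assay.
Compound 3 `CC(C)CCN(C)Cc1cn(C2CCCCC2OC(=O)COc2ccccc2)nn1` gives 59% in this assay.

Compound 3 stands highest of the three numbers; the nearest is compound 2 and the furthest compound 1. Among the measured compounds shown here, the only measured step, a number 17 percentage points higher from compound 2 to compound 3 (beyond the scatter), shows that the (phenoxymethyl)carbonyl group raised inhibition beyond the scatter. Compound 4 `CC(C)CCN(C)Cc1cn(C2CCCCC2OC(=O)c2ccccc2)nn1` differs from compound 3 by phenyl in place of phenoxymethyl on a carbonyl carbon. For the measured compounds named here, no measured pair shows this exchange. Compound 1 bears the same benzoyl ester, with a different amine, and gives a number well below compound 3. Compound 4 is therefore expected to lie between, with a number 15 percentage points lower from compound 3 to compound 4 (beyond the scatter) a loss beyond the scatter. The estimate for compound 4 is 44%, within 26% to 62%.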

Compound 4, a percentage reported as inhibition, at one concentration (the size of the read-out at that concentration, not a potency): 26%
Estimate against measurement, compound 4: 18 percentage points above; measured number inside the range.
By their numbers in this assay, from the lowest: compounds 4, 1 and 2 (each within the scatter of the next, the first and the last beyond it); then compound 3.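

In this assay, the group on the carbonyl carbon decides the outcome: phenyl in place of phenoxymethyl gives a number 33 percentage points lower from compound 3 to compound 4 (beyond the scatter). Esterifying the oxygen brings no gain in itself, since benzoyl in place of hydrogen gives a number 16 percentage points lower from compound 2 to compound 4 (beyond the scatter), opposite in direction to a number 17 percentage points higher from compound 2 to compound 3 (beyond the scatter). Among the benzoyl esters, isobutyl in place of cyclohexyl gives a number 6 percentage points lower from compound 1 to compound 4 (within the scatter), so this exchange does not separate them.

Nothing shown explains why phenoxymethyl and phenyl differ so strongly. From the compounds shown here alone, whether a longer chain or an amine in place of phenoxymethyl would hold the higher number also stays open.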